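The source may report more compounds than this note shows. Statements on the series, on what has been measured and on what is new or still open speak of the compounds shown alone.

Measured compounds:
compound 1 `CC/C(=C(/c1ccc(/C=C/C(=O)O)cc1)c1ccc(O)nc1)c1ccccc1` — "not determined" (no result reported);
compound 2 `CC/C(=C(/c1ccc(/C=C/C(=O)O)cc1)c1ccc2[nH]ncc2c1)c1ccccc1` — 6 nM;
compound 3 `CC/C(=C(/c1ccc(/C=C/C(=O)O)c(C)c1)c1ccc2[nH]ncc2c1)c1ccccc1` — 14 nM.

In a functional assay on MCF7 cells (Homo sapiens) for cytotoxicity, read by CellTiter-Glo, with a stated time of 5 days (on this read-out lower numbers stand for stronger inhibition and higher numbers for weaker inhibition), compound 2 gives 6 nM, the lowest of the two numbers at hand; its nearest neighbour, compound 3, gives 14 nM. Compound 1 has no result in this assay. Among the compounds with values here, the single step with a number, a 2.3-fold higher number from compound 2 to compound 3 (0.37 log units; beyond the scatter), concerns a methyl added on an aromatic carbon and lies beyond the usual scatter, though only modestly.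

Compound 4 `CC/C(=C(/c1ccc(/C=C/C(=O)O)cc1)c1ccc2[nH]ncc2c1)c1cccnc1C` is not yet measured. Its difference from compound 2 is 2-methylpyridin-3-yl in place of phenyl on a double-bonded chain carbon bound to a double-bonded chain carbon and a saturated chain carbon. Within the data shown here, no measured step concerns this change; the one available step, from compound 2 to compound 3, alters a different part of the molecule, so it offers only a loose sense of how much a small change can move the number here. With a ring nitrogen and a methyl both entering, a step of about the same modest size, toward a higher number, is the expectation, though a result within the scatter would not be surprising. Compound 4 is therefore expected to give 12 nM in this assay, in the range 5 nM to 30 nM, corresponding to an expected step of a 2.0-fold higher number from compound 2 to compound 4 (0.30 log units; within the scatter).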

Compound 4, half-maximal inhibitory concentration: 200 nM
Compound 4: the middle estimate sits 17-fold (1.22 log units) below what was measured; measured number outside the range, above it.
By their numbers in this assay, from the lowest: compound 2; then compound 3; then compound 4.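

Replacing phenyl with 2-methylpyridin-3-yl on the double-bonded chain carbon gives a 33-fold higher number from compound 2 to compound 4 (1.52 log units; beyond the scatter) in this assay. This large step contrasts with the modest 2.3-fold higher number from compound 2 to compound 3 (0.37 log units; beyond the scatter), which comes from a methyl placed elsewhere in the molecule. Within the data shown here, of the two places changed so far, this is therefore the one where the number moves more, and the phenyl cannot be exchanged for this ring without a clear loss of inhibition in these cells; no measurement at hand explains the size of this loss.

Going by these compounds, the two changes entered together, so it remains open whether the ring nitrogen, the methyl or their combination accounts for the step. A phenyl carrying only the methyl and a pyridine ring without the methyl would separate these possibilities.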